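Uracil derivatives with benzyl-protected diol side chains on liver cancer cells

This account rests on a few compounds, and the source may have more. Where it says the series, first, only, none or still open, it means among the compounds named here.

Compound 1 `COCn1c(CC(O)(COCc2ccccc2)COCc2ccccc2)cc(=O)[nH]c1=O` was tested in a functional assay on HepG2 cells (Homo sapiens) for antiproliferative activity, read by MTT assay, with a stated time of 72 h; on this read-out lower numbers stand for stronger inhibition and higher numbers for weaker inhibition; in this assay compound 1 reaches only the limit > 100000 nM. Compound 2 `C[Si](C)(C)CCOCn1c(CC(O)(COCc2ccccc2)COCc2ccccc2)cc(=O)[nH]c1=O` likewise reaches only the limit > 100000 nM in this assay. Compound 3 `Cc1c(CC(O)COCc2ccccc2)n(COCC[Si](C)(C)C)c(=O)[nH]c1=O` also gives only the limit > 100000 nM in this assay.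

For the measured compounds named here, the one change that links two measured compounds is a hydrogen atom in place of a group of 5 heavy atoms (4 carbon, 1 silicon; no ring), on a saturated chain carbon bound to an oxygen on a saturated carbon; the step that the two limits leave unreadable from compound 2 to compound 1 cannot be sized because both ends are limits. The difference between the cores of compound 3 and compound 2 is not broken down here. Compound 4 `COCn1c(CC(O)COCc2ccccc2)c(C)c(=O)[nH]c1=O` has not yet been measured in this assay. It is made from compound 3 by a hydrogen atom in place of a group of 5 heavy atoms (4 carbon, 1 silicon; no ring), on a saturated chain carbon bound to an oxygen on a saturated carbon, and since the place is described in the same words as for the step from compound 2 to compound 1, this is the same change. Going by the values given here, the only evidence bearing on it is the limit of > 100000 nM in this assay, at which 3 of the 3 values shown sit: every value so far sits at the limit.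

On that basis compound 4 is expected to show the step that the limit leaves unreadable from compound 3 to compound 4, which rests on the step from compound 2 to compound 1 leaving both ends at the limit. The estimate for compound 4 in this assay is therefore 200000 nM, with the range 40000 nM to 1000000 nM, and most likely the assay will again report only a limit.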

Compound 4, half-maximal inhibitory concentration: > 100000 nM
Compound 4 ended at the assay's limit; the forecaster's own chance of this, stated with the estimate: 85%; the middle value lies beyond the limit too.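

No new step can be read between compound 3 and compound 4, as each of the two is recorded only as a limit in this assay. The compounds shown leave open how large the replacement of this group by hydrogen really is, and whether any change to these structures would give a readable value in this assay: the limit of > 100000 nM in this assay, at which 4 of the 4 values shown sit.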